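A Methyl on the Benzylic Carbon of Compound 3

The source may report more compounds than this note shows. Statements on the series, on what has been measured and on what is new or still open speak of the compounds shown alone.

The three measured compounds share a common core and differ in what is attached on its carbocyclic side. In an ADME assay on HEK293 cells for agonist activity at Toll-like receptor 8 (Homo sapiens), read by a luciferase reporter, with a stated time of 6 h (a lower number here means that less compound is needed, a higher number that more compound is needed for the effect), compound 1 (`CCCCNc1nc(N)nc2cc(CO)ccc12`) gives 0.1 uM, compound 2 (`CCCCNc1nc(N)nc2cccc(OCc3ccccn3)c12`) gives 18.5 uM, and compound 3 (`CCCCNc1nc(N)nc2cccc(C(=O)NCc3ccccc3)c12`) gives 1.6 uM. Among these three numbers compound 3 holds the second highest; its nearest neighbour is compound 2, whose number is higher by a margin beyond the scatter, and its furthest is compound 1, whose number is lower, again beyond the scatter. Going by the values given here, no pair of measured compounds differs in a single place, so no measured step is available to lean on.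

Compound 4 (`CCCCNc1nc(N)nc2cccc(C(=O)N[C@@H](C)c3ccccc3)c12`) differs from compound 3 in one place: methyl in place of hydrogen on a saturated chain carbon bound to an amide-type nitrogen and an aromatic carbon. Among the compounds with values here, nothing among the measured compounds shows how this change behaves; the only anchor is that compound 3 itself stands at 1.6 uM. A step of modest size is expected for a 1.6-fold lower number from compound 3 to compound 4 (0.20 log units; within the scatter) in this assay, leaning toward a somewhat lower number but not clearly beyond the scatter. Compound 4 is therefore estimated at 1 uM, with a range from 0.3 uM to 4 uM.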

Compound 4, minimum effective concentration: > 25 uM
Compound 4: a limit, no number (the forecaster's own chance of this, stated with the estimate: 5%); at least 25-fold (1.39 log units) between middle value and limit.
By their numbers in this assay, from the lowest: compound 1; then compound 3; then compound 2. At a limit, above all of these: compound 4.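

In this assay, going by these compounds alone, the single added methyl, on a saturated chain carbon bound to an amide-type nitrogen and an aromatic carbon, gives an at least 15-fold higher number from compound 3 to compound 4 (1.19 log units; beyond the scatter), the first step in this set that can be read at one place and a large one for a change of one heavy atom. Within the data shown here, compound 4 reads > 25 uM, which is a limit of the assay and not a number, so the step gives only the least size of the change and not its full size: the limit of > 25 uM in this assay, at which 1 of the 4 values shown sits. This carbon is therefore not indifferent to substitution, since going from benzyl to 1-phenylethyl is enough to carry compound 3, which has a measurable number, to the limit, something the earlier compounds, with no pair among them differing in one place, could not show.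

The compounds shown leave open whether this shift belongs to the methyl as such or to the one spatial arrangement drawn at that carbon, as the opposite hand of the 1-phenylethyl group does not appear among them. They also leave open whether fluorine, a longer chain such as ethyl, or a hydroxymethyl on the same carbon would behave as the methyl does.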